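This account rests on a few compounds, and the source may have more. Where it says the series, first, only, none or still open, it means among the compounds named here.

Working notes on the aminopyrimidine series.

Compound 1 `COc1ccc(-c2cc(-c3ccccc3O)nc(N)n2)cc1` is the reference point. In an ADME assay on MT4 cells (Homo sapiens) for cytotoxicity, read by MTT assay, with a stated time of 5 days (on this read-out higher numbers stand for lower toxicity in this test and lower numbers for higher toxicity in this test), compound 1 gives 92200 nM. Compound 2 `Nc1nc(-c2ccc(Cl)cc2)cc(-c2ccccc2O)n1` differs from compound 1 by chloro in place of methoxy on an aromatic carbon. In this assay compound 2 is reported only as a limit, > 74700 nM. The step that the limit leaves unreadable from compound 1 to compound 2 is therefore not readable in size, because the limit of > 74700 nM in this assay, at which 1 of the 3 values shown sits, sets the ceiling of what the read-out can show for compound 2.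

Compound 3 `COc1cccc(-c2cc(-c3ccccc3O)nc(N)n2)c1` has the same atoms as compound 1, joined differently; the difference between the two cores is not broken down here. In this assay compound 3 is reported only as a limit, > 78300 nM, in line with the limit of > 78300 nM in this assay, at which 1 of the 3 values shown sits.

Compound 4 `Nc1nc(-c2cccc(Cl)c2)cc(-c2ccccc2O)n1` is not yet measured. It differs from compound 3 by chloro in place of methoxy on an aromatic carbon. This is the same kind of change as from compound 1 to compound 2, the place differing in that the entering chloro sits meta to a large group in compound 4 where it sits para to a large group in compound 2.

The expectation for compound 4 rests on compound 2, whose value > 74700 nM is a limit, and on compound 3, whose value > 78300 nM is a limit, so compound 4 is expected to land in the same region, most likely again as a limit. The step from compound 3 to compound 4 is expected to be a step that the limit leaves unreadable from compound 3 to compound 4. Compound 4 is estimated at 80000 nM, within an expected span from 40000 nM to 200000 nM.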

Compound 4, half-maximal cytotoxic concentration: > 125000 nM
Compound 4: no number, only a limit; the forecaster's own chance of this, stated with the estimate: 70%; middle value at least 1.5-fold (0.19 log units) from the limit.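

In this assay compound 4 is reported only as a limit, > 125000 nM. With compound 2 and compound 3 also standing as limits, no step to compound 4 from either can be read in size: the limit of > 125000 nM in this assay, at which 1 of the 4 values shown sits.

The compounds shown leave open whether chloro in place of methoxy changes the cytotoxicity read-out at all, and whether 3-chlorophenyl and 4-chlorophenyl differ in it.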